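Replacing 3,4,5-trimethoxyphenyl with 2-hydroxyphenyl on the shared core

The source may hold more compounds than are shown below. What is called first, only, known or untested is meant among the compounds shown, and "the series" means these compounds.

In a toxicity assay on CHO cells (Cricetulus griseus) for cytotoxicity, read by MTT assay (on this read-out lower numbers stand for stronger inhibition and higher numbers for weaker inhibition), compound 1 `O=C(N/N=C/c1ccccc1)c1cn(C2CC2)c2cc(N3CCNCC3)c(F)cc2c1=O` gives 25000 nM. Compound 2 `COc1cc(/C=N/NC(=O)c2cn(C3CC3)c3cc(N4CCNCC4)c(F)cc3c2=O)cc(OC)c1OC` gives 25000 nM, which places it level with compound 1, its nearest neighbour on these numbers.

The next compound, compound 3 `O=C(N/N=C/c1ccccc1O)c1cn(C2CC2)c2cc(N3CCNCC3)c(F)cc2c1=O`, has not yet been measured. It differs from compound 2 at a single place: 2-hydroxyphenyl in place of 3,4,5-trimethoxyphenyl on a carbon with a double bond to nitrogen. In words, 2-hydroxyphenyl stands in place of 3,4,5-trimethoxyphenyl on a carbon with a double bond to nitrogen.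

Going by the values given here, only one measured step bears on this change, and it concerns the same place: no change at the digits printed from compound 1 to compound 2 (within the scatter), with 3,4,5-trimethoxyphenyl in place of phenyl. That step stays within the scatter. Among the compounds with values here, no measured compound carries 2-hydroxyphenyl, however, so the data offer no direct evidence for this group, and a single step is thin support. With that limitation, no shift beyond the scatter is expected in this assay, and the expected step is a 1.3-fold lower number from compound 2 to compound 3 (0.10 log units; within the scatter). The estimate for compound 3 is 20000 nM, with an expected range from 7000 nM to 40000 nM.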

Compound 3, half-maximal inhibitory concentration: 25000 nM
Beside the measured number, compound 3's estimate is 1.3-fold (0.10 log units) below it, within the range that was stated.
By their numbers in this assay, from the lowest: compounds 1, 2 and 3 (each within the scatter of the next).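

In this assay the replacement of 3,4,5-trimethoxyphenyl by 2-hydroxyphenyl on a carbon with a double bond to nitrogen gives no change at the digits printed from compound 2 to compound 3 (within the scatter) and hydroxy in place of hydrogen on an aromatic carbon gives no change at the digits printed from compound 1 to compound 3 (within the scatter). Going by these compounds alone, this is the first reading at this place for a group with 1 hydrogen-bond donor, and it shows that compounds 1, 2 and 3 stand level here even though the group entering compound 3 has 7 heavy atoms, fewer than the one leaving compound 2. No information is available on why these three compounds stand level in this assay.

Going by these compounds, whether an amine or a carboxylic acid on the aromatic ring at this place, or a longer chain in place of that ring, would take the number beyond the scatter remains open. Also open, on these data alone, is whether compounds 1, 2 and 3 would stand level on any read-out other than this assay, since the three values shown all come from this one assay.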